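Replacing the thiazoline side chain with a phenylpiperazine

A few compounds are considered here, and "the series" means these few. Any claim that something is new, unique, unknown or untested is made for them only; others in the source may bear on it.

Compound 2 `Cn1c(-c2ccc(NC(=O)CSC3=NCCS3)cc2)nc(-c2ccccc2)c1-c1ccccc1` stands lowest of the two compounds measured in a functional assay on HT-29 cells (Homo sapiens) for cytotoxicity, read by MTT assay, with a stated time of 24 h, tested at 32 ug/mL; a higher number here means a stronger effect of the compound at the concentration tested, a lower number a weaker effect: compound 2 gives 59.4%, while compound 1 `Cn1c(-c2ccc(NC(=O)CSc3nc4ccccc4o3)cc2)nc(-c2ccccc2)c1-c1ccccc1` gives 79.3%. Among the measured compounds shown here, the single measured step, a number 19.9 percentage points lower from compound 1 to compound 2 (beyond the scatter), exchanged only the group on the sulfur. Compound 3 `Cn1c(-c2ccc(NC(=O)CN3CCN(c4ccccc4)CC3)cc2)nc(-c2ccccc2)c1-c1ccccc1` alters a different part of the chain: a group of 12 heavy atoms (10 carbon, 2 nitrogen; one six-membered non-aromatic ring with 2 hetero atoms, one six-membered aromatic ring of carbon only) in place of a group of 6 heavy atoms (3 carbon, 1 nitrogen, 2 sulfur; one five-membered non-aromatic ring with 2 hetero atoms), on a saturated chain carbon bound to a carbonyl carbon. The sulfur itself now leaves, so the step of a number 19.9 percentage points lower from compound 1 to compound 2 (beyond the scatter) bears on this change only indirectly; it shows that a swap of the group carried at this end of the chain moved the read-out by a modest amount. Compound 3 is therefore expected to differ from compound 2 by a step of modest size and uncertain direction, given as a number 2.6 percentage points higher from compound 2 to compound 3 (within the scatter). The estimated value for compound 3 is 62%, within a range from 40% to 84%.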

Compound 3, a percentage reported as activity, at one concentration (the size of the read-out at that concentration, not a potency): 60.5%
For compound 3 the middle estimate is 1.5 percentage points above the measured one, within the range that was stated.
By their numbers in this assay, from the lowest: compounds 2 and 3 (each within the scatter of the next); then compound 1.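

In this assay, 4-phenylpiperazin-1-yl on a saturated chain carbon bound to a carbonyl carbon gives a number 1.1 percentage points higher from compound 2 to compound 3 (within the scatter), so two side chains that share little in atom count or ring type cannot be told apart here, even though the sulfur leaves with the second group. Among the compounds shown here, the other new step, a number 18.8 percentage points lower from compound 1 to compound 3 (beyond the scatter), is close in size to a number 19.9 percentage points lower from compound 1 to compound 2 (beyond the scatter), which leaves (1,3-benzoxazol-2-yl)sulfanyl as the only group of the three that stands apart from the others in this read-out. No evidence is available that would explain this result.

On these data alone, it remains open whether the fused aromatic ring or the sulfur link matters more, which a (1,3-benzothiazol-2-yl)sulfanyl group or a plain benzyl group could help to separate. A simple amine such as morpholine, a carboxylic acid or a longer chain at this carbon also remains untested in the compounds shown here.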